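Replacing 1-fluoro-1-methylethyl with 2,2-difluoroethoxy in compound 3

This account rests on a few compounds, and the source may have more. Where it says the series, first, only, none or still open, it means among the compounds named here.

Compound 1 `N#Cc1cnc(NCc2ccccc2C(F)(F)F)cc1N[C@H]1C[C@@H](C(N)=O)C1`: 86%
Compound 2 `N#Cc1cnc(NCc2cnccc2C(F)(F)F)cc1N[C@H]1CC[C@@H](n2cncn2)CC1`: 64%
Compound 3 `CC(C)(F)c1ncncc1CNc1cc(N[C@H]2CC[C@@H](O)CC2)c(C#N)cn1`: 89%

In an ADME assay on S9 fraction from liver (Homo sapiens) for metabolic stability, with a stated time of 1 h (a higher number here means that more of the compound is left, a lower number that less of the compound is left), compound 3 gives 89%. Compound 1 gives 86%, and the gap between these two compounds lies within the scatter. Compound 2 gives 64%. The gap between compound 3 and compound 2 lies beyond the scatter, with compound 2 the lower of the two. Compound 4 `N#Cc1cnc(NCc2cncnc2OCC(F)F)cc1N[C@H]1CC[C@@H](O)CC1` has 2,2-difluoroethoxy in place of 1-fluoro-1-methylethyl on an aromatic carbon. Among the measured compounds shown here, no two measured compounds differ in one place only, so the data offer no direct guide to this change. The expectation therefore starts from compound 3 at 89% and allows for a small fall within the scatter in this assay. The expected step is a number 8 percentage points lower from compound 3 to compound 4 (within the scatter). For compound 4, the estimate is 81%, with an expected range of 63% to 95%.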

Compound 4, percent of the compound remaining: 87%
For compound 4 the middle estimate is 6 percentage points below the measured one; low and high end bracket the measured number.
By their numbers in this assay, from the lowest: compound 2; then compounds 1, 4 and 3 (each within the scatter of the next).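

Among the compounds shown here, the step of a number 2 percentage points lower from compound 3 to compound 4 (within the scatter) in this assay is the first comparison in this set between compounds that differ in one place. It shows that, on this aromatic carbon, 2,2-difluoroethoxy can stand in place of 1-fluoro-1-methylethyl, bringing in an oxygen, with the change staying within the scatter. Nothing available explains this result.

The compounds shown leave open how an amine or a longer alkyl chain at this position would read in this assay. They also leave open whether the same exchange would read alike on compounds whose other parts differ, such as compound 2.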